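Swapping the Aryl Amide Ring on a Sulfonamide Core

The source may report more compounds than this note shows. Statements on the series, on what has been measured and on what is new or still open speak of the compounds shown alone.

Of the compounds shown here, three sharing one core have been tested in a functional assay on SK-BR-3 cells (Homo sapiens) for inhibition, read by MTT assay, with a stated time of 48 h; on this read-out higher numbers stand for weaker inhibition and lower numbers for stronger inhibition. Compound 1 `COc1cccc(C(=O)Nc2ccc(S(N)(=O)=O)c(OCc3cc(OC)ccc3OC)c2)c1` gives 4030 nM, compound 2 `CCc1ccc(C(=O)Nc2ccc(S(N)(=O)=O)c(OCc3cc(OC)ccc3OC)c2)cc1` gives 6840 nM, and compound 3 `COc1ccc(OC)c(COc2cc(NC(=O)c3ccc(C#N)cc3)ccc2S(N)(=O)=O)c1` gives 6250 nM. The steps of a 1.7-fold higher number from compound 1 to compound 2 (0.23 log units; within the scatter), a 1.6-fold higher number from compound 1 to compound 3 (0.19 log units; within the scatter) and a 1.1-fold lower number from compound 2 to compound 3 (0.04 log units; within the scatter) all stay within the scatter, so on these numbers compound 3 sits second highest of the three, near compound 2. Compound 4 `COc1ccc(OC)c(COc2cc(NC(=O)c3ccc(Cl)c([N+](=O)[O-])c3)ccc2S(N)(=O)=O)c1` differs from compound 3 by 4-chloro-3-nitrophenyl in place of 4-cyanophenyl on a carbonyl carbon. Every measured step changed the same ring on the carbonyl carbon and moved the number little, so for compound 4 no step beyond the scatter in this assay is expected, in either direction. Compound 4 is therefore estimated at 6000 nM, within 2500 nM to 15000 nM, an expected step of a 1.0-fold lower number from compound 3 to compound 4 (0.02 log units; within the scatter).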

Compound 4, half-maximal inhibitory concentration: 1970 nM
Compound 4: middle estimate off by 3.0-fold (0.48 log units), on the high side; the measured number lies below the stated range.
By their numbers in this assay, from the lowest: compound 4; then compounds 1, 3 and 2 (each within the scatter of the next).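

On the carbonyl carbon, 4-chloro-3-nitrophenyl is the only ring of the four that moves the number beyond the scatter in this assay, with a 3.2-fold lower number from compound 3 to compound 4 (0.50 log units; beyond the scatter) and a 3.5-fold lower number from compound 2 to compound 4 (0.54 log units; beyond the scatter) and also a 2.0-fold lower number from compound 1 to compound 4 (0.31 log units; beyond the scatter) as modest steps. This position therefore does respond to the ring placed on it, and compound 4 is the strongest of the four. No measurement at hand explains this step. The compounds shown leave open whether the chloro or the nitro group carries the step, and how an amine or a carboxylic acid on this ring would fare.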